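The source may hold more compounds than are shown below. What is called first, only, known or untested is meant among the compounds shown, and "the series" means these compounds.

Compound 1 `FC(F)(F)Oc1ccc(-c2nc3cnc(Nc4ccccn4)cc3[nH]2)cc1`: < 5000 nM
Compound 2 `FC(F)(F)c1cccc(-c2nc3cnc(Nc4ccncn4)cc3[nH]2)c1`: < 5000 nM

In a physicochemical assay for solubility, using the shake flask method, in phosphate buffer, measured as kinetic solubility, with a stated time of 20 h, at pH 6.5 (a higher number here means a more soluble compound, a lower number a less soluble compound), compound 1 reads < 5000 nM, which is a limit and not a number. Compound 2 reads < 5000 nM, also a limit of the assay. Among the measured compounds shown here, compound 2 therefore has no exact place on the scale, and no step between measured compounds gives a size to work from. Compound 3 `FC(F)(F)c1ccc(Nc2cc3[nH]c(-c4cccc(C(F)(F)F)c4)nc3cn2)nc1` differs from compound 2 in one place: 5-(trifluoromethyl)pyridin-2-yl in place of pyrimidin-4-yl on a nitrogen on an aromatic ring. In this assay a modest drop is expected, and the estimated change is a step that the limit leaves unreadable from compound 2 to compound 3. Compound 3 is expected to read about 2000 nM, within an estimated range of 500 nM to 5000 nM.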

Compound 3, solubility: < 5000 nM
Compound 3 gave a limit, no number (the forecaster's own chance of this, stated with the estimate: 90%); the middle value does not contradict the limit.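

Among the compounds shown here, no step from compound 2 to compound 3 can be read in this assay because both compounds give only a limit: the limit of < 5000 nM in this assay, at which 3 of the 3 values shown sit.
The compounds shown leave open whether 5-(trifluoromethyl)pyridin-2-yl in place of pyrimidin-4-yl changes the solubility at all.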